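Vinylpyrimidine for vinylpyridine on the alkyne arm

This account rests on a few compounds, and the source may have more. Where it says the series, first, only, none or still open, it means among the compounds named here.

Compound 3 `C=Cc1ccnc(C#Cc2ccc3ncn(-c4ccnc(N)n4)c3c2)c1` gives 1580 nM in an assay on Sf9 cells for inhibition of mitogen-activated protein kinase kinase kinase 14 variant S549D (Homo sapiens), with a stated time of 30 min, in the presence of a further agent that is not named here (a higher number here means a weaker inhibitor, a lower number a stronger inhibitor), the lowest of the two numbers shown. Compound 1 `C=CC(=O)NCCCCc1ccc2ncn(-c3ccnc(N)n3)c2c1` gives 501000 nM in this assay. Compound 2 `CC(=O)NCCCc1ccc2ncn(-c3ccnc(N)n3)c2c1` reaches only the limit > 100000 nM in this assay. Among the compounds with values here, the single measured step, a step that the limit leaves unreadable from compound 1 to compound 2, stays unreadable because of the limit of > 100000 nM in this assay, at which 1 of the 3 values shown sits. Compound 4 `C=Cc1nccc(C#Cc2ccc3ncn(-c4ccnc(N)n4)c3c2)n1` differs from compound 3 by a group of 8 heavy atoms (6 carbon, 2 nitrogen; one six-membered aromatic ring with 2 hetero atoms) in place of a group of 8 heavy atoms (7 carbon, 1 nitrogen; one six-membered aromatic ring with 1 hetero atom), on a triple-bonded carbon. Within the data shown here, no measured step touches the ring at the end of the alkyne; the unreadable step concerns a saturated chain carbon instead, so nothing measured bears directly on this change. The expectation for compound 4 is therefore a step of a 1.3-fold higher number from compound 3 to compound 4 (0.10 log units; within the scatter), not beyond the scatter. Compound 4 is estimated at 2000 nM, within 600 nM to 7000 nM.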

Compound 4, half-maximal inhibitory concentration: 39800 nM
The estimate for compound 4 lay 20-fold (1.30 log units) below the measured number; measured number above the stated range.
By their numbers in this assay, from the lowest: compound 3; then compound 4; then compound 1.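

In this assay, the ring at the end of the alkyne proves sensitive: a six-membered aromatic ring with 2 hetero atoms in place of one with 1 hetero atom, on a triple-bonded carbon, gives a 25-fold higher number from compound 3 to compound 4 (1.40 log units; beyond the scatter). The heavy-atom count stays the same, so this position responds to a change within the ring itself, which the earlier chain compounds could not show. Nothing measured here accounts for the size of this step. Open, as far as these compounds go, is how a plain phenyl ring would behave at this place, and whether an ethyl group could replace the vinyl group on either ring.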